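This account rests on a few compounds, and the source may have more. Where it says the series, first, only, none or still open, it means among the compounds named here.

Measured compounds:
compound 1 `COc1cc(NC(=O)Nc2cc(Nc3cccc(C(C)(C)C)c3)ncn2)cc(OC)c1` — 68%
compound 2 `COc1cc(NC(=O)Nc2cc(Nc3cc(Br)ccc3OC)ncn2)cc(OC)c1` — 82.5%

For the measured compounds named here, in a functional assay on PC-9 cells (Homo sapiens) for inhibition, read by MTT assay, with a stated time of 48 h, tested at 10 uM (on this read-out higher numbers stand for more inhibition at the one concentration tested (going by the name of the read-out) and lower numbers for less inhibition), compound 1 gives 68%, the lower of the two numbers; the only measured step is a number 14.5 percentage points higher from compound 1 to compound 2 (beyond the scatter), a change on a nitrogen on an aromatic ring. Compound 3 `CC(C)(C)c1cccc(Nc2cc(NC(=O)Nc3c(Cl)cccc3Cl)ncn2)c1` differs from compound 1 at another place: 2,6-dichlorophenyl in place of 3,5-dimethoxyphenyl on an amide-type nitrogen. Going by the values given here, no measured step touches that part of the shared core, so nothing here tells how this change affects the read-out. A step of no size beyond the scatter is therefore expected, no change at the digits printed from compound 1 to compound 3 (within the scatter). Compound 3 is estimated at 68%, with a range from 45% to 85%.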

Compound 3, a percentage reported as inhibition, at one concentration (the size of the read-out at that concentration, not a potency): 87.1%
Estimate against measurement, compound 3: 19.1 percentage points below, outside the stated range (above it).
By their numbers in this assay, from the lowest: compound 1; then compounds 2 and 3 (each within the scatter of the next).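

In this assay, 2,6-dichlorophenyl in place of 3,5-dimethoxyphenyl on the amide-type nitrogen gives a number 19.1 percentage points higher from compound 1 to compound 3 (beyond the scatter) and so shows that the read-out responds to this end of the molecule, not only to the group on the nitrogen on an aromatic ring. No measurement here explains why this change raises the number.

The compounds shown leave open whether a single chlorine on the phenyl ring would give a similar number. They also leave open how a morpholine or a carboxylic acid would read on this amide-type nitrogen.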